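The source may hold more compounds than are shown below. What is called first, only, known or untested is meant among the compounds shown, and "the series" means these compounds.

Working notes on the series. In a functional assay on HepG2 cells (Homo sapiens) for antiproliferative activity, read by MTT assay, with a stated time of 72 h (on this read-out higher numbers stand for weaker inhibition and lower numbers for stronger inhibition), compound 3 `COc1ccc(-c2cn(C[C@H](O)[C@H]3OC(=O)C(OCc4ccccc4)=C3OCc3ccccc3)nn2)cc1` gives 46400 nM, a number that sits between those of compound 1 `O=C1O[C@H]([C@@H](O)Cn2cc(-c3cccc(O)c3)nn2)C(OCc2ccccc2)=C1OCc1ccccc1` at 62700 nM and compound 2 `O=C1O[C@H]([C@@H](O)Cn2cc(CNS(=O)(=O)c3ccc(Cl)cc3F)nn2)C(OCc2ccccc2)=C1OCc1ccccc1` at 25500 nM, each within the usual scatter of it. Compound 4 `O=C1O[C@H]([C@@H](O)Cn2cc(CCO)nn2)C(OCc2ccccc2)=C1OCc1ccccc1` differs from compound 3 by 2-hydroxyethyl in place of 4-methoxyphenyl on an aromatic carbon. Within the data shown here, the only measured step at that position is a 1.4-fold lower number from compound 1 to compound 3 (0.13 log units; within the scatter), an exchange of one aryl group for another; no measured pair exchanges an aryl group for a short chain, so the change into compound 4 is not directly covered. With the three numbers this close, no step beyond the scatter is expected, and compound 4 is estimated at 55000 nM, between 22000 nM and 140000 nM, which would mean a 1.2-fold higher number from compound 3 to compound 4 (0.07 log units; within the scatter).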

Compound 4, half-maximal inhibitory concentration: 68100 nM
Compound 4: middle estimate off by 1.2-fold (0.09 log units), on the low side; the range from low to high includes it.
By their numbers in this assay, from the lowest: compounds 2, 3, 1 and 4 (each within the scatter of the next, the first and the last beyond it).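

Exchanging either aryl group for the 2-hydroxyethyl chain removes the six-membered aromatic ring, yet both steps stay within the scatter (a 1.5-fold higher number from compound 3 to compound 4 (0.17 log units; within the scatter); a 1.1-fold higher number from compound 1 to compound 4 (0.04 log units; within the scatter)). Only the exchange of ((4-chloro-2-fluorophenyl)sulfonyl)amino for hydroxymethyl on a saturated chain carbon bound to an aromatic carbon goes beyond it, and only modestly (a 2.7-fold higher number from compound 2 to compound 4 (0.43 log units; beyond the scatter)). Nothing at hand accounts for these steps. As far as these compounds go, whether an amine, a carboxylic acid or a longer chain in place of 2-hydroxyethyl on this aromatic carbon would move the number beyond the scatter stays open.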